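Swapping the Ring Nitrogen Substituent and Cell Growth Inhibition

A few compounds are considered here, and "the series" means these few. Any claim that something is new, unique, unknown or untested is made for them only; others in the source may bear on it.

Measured compounds:
compound 1 `Nc1ccccc1NC(=O)c1ccc(CSC(=S)N2CCN(Cc3ccccn3)CC2)cc1`: 65.2%
compound 2 `Nc1ccccc1NC(=O)c1ccc(CSC(=S)N2CCN(c3ccc(Cl)cc3)CC2)cc1`: 17.2%
compound 3 `Nc1ccccc1NC(=O)c1ccc(CSC(=S)N2CCN(c3ccccc3F)CC2)cc1`: 86.4%

In a functional assay on MGC-803 cells (Homo sapiens) for antiproliferative activity, read by CCK-8 assay, with a stated time of 72 h, tested at 8 uM (on this read-out lower numbers stand for a weaker effect and higher numbers for a stronger effect at the one concentration tested), compound 1 gives 65.2%, the second highest of the three numbers. Compound 3 stands above it, a number 21.2 percentage points higher from compound 1 to compound 3 (beyond the scatter), while compound 2 stands far below, a number 48 percentage points lower from compound 1 to compound 2 (beyond the scatter). Between the two aryl-bearing compounds the gap is the widest of all, a number 69.2 percentage points higher from compound 2 to compound 3 (beyond the scatter).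

Compound 4 `N#Cc1ccc(N2CCN(C(=S)SCc3ccc(C(=O)Nc4ccccc4N)cc3)CC2)cc1` is not yet measured. It differs from compound 1 in one place: 4-cyanophenyl in place of (pyridin-2-yl)methyl on an amine nitrogen in a ring. The two steps that start from compound 1 bear on this change, and they point in opposite directions: an aryl group in place of (pyridin-2-yl)methyl gave a large fall with 4-chlorophenyl and a modest rise with 2-fluorophenyl. The data hold no aryl group carrying a nitrile, so neither step can be taken as a direct guide. Because of the spread between 17.2% for compound 2 and 86.4% for compound 3, a step in either direction beyond the scatter is possible, and a downward one cannot be excluded.

Compound 4 is therefore expected to reach 45% in this assay, within a range from 12% to 80%. This expectation corresponds to an estimated step of a number 20.2 percentage points lower from compound 1 to compound 4 (beyond the scatter).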

Compound 4, a percentage reported as inhibition, at one concentration (the size of the read-out at that concentration, not a potency): 37.6%
Compound 4: middle estimate off by 7.4 percentage points, on the high side; measured number inside the range.
By their numbers in this assay, from the lowest: compound 2; then compound 4; then compound 1; then compound 3.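

In this assay, a nitrile-bearing aryl group on the amine nitrogen in the ring also falls short of (pyridin-2-yl)methyl, with a number 27.6 percentage points lower from compound 1 to compound 4 (beyond the scatter), so the 4-chlorophenyl and 4-cyanophenyl compounds both lie under compound 1, while the 2-fluorophenyl of compound 3 goes against that pattern. Replacing 2-fluorophenyl with 4-cyanophenyl gives a number 48.8 percentage points lower from compound 3 to compound 4 (beyond the scatter), whereas cyano in place of chloro on an aromatic carbon gives a number 20.4 percentage points higher from compound 2 to compound 4 (beyond the scatter), which shows that the outcome at this nitrogen depends on what the phenyl ring carries and not on the presence of a phenyl ring alone. Nothing in the data gives a measured property of these groups that would account for these differences.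

The compounds shown leave open whether the high number of compound 3 belongs to fluoro as such or to the 2-fluorophenyl group specifically, since neither 4-fluorophenyl nor 2-chlorophenyl appears among them. None of the compounds shown carries a benzyl group. The data do not separate the pyridine ring of compound 1 from its methylene link.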